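Exchanging the nitrophenyl of compound 1 for trichlorophenyl

The source may report more compounds than this note shows. Statements on the series, on what has been measured and on what is new or still open speak of the compounds shown alone.

This account follows a single change on the amide of a shared core. Within the data shown here, compound 1 `Cc1ccc(S(=O)(=O)NCc2ccc(CNC(=O)c3ccc([N+](=O)[O-])cc3)cc2)cc1` is the reference; in an assay on MDA-MB-231 cells for binding affinity to C-X-C chemokine receptor type 4 (Homo sapiens), read by immunofluorescence and microscopy, with stated times of 10 min and 30 min (a higher number here means that more compound is needed for the effect, a lower number that less compound is needed), compound 1 gives 10 nM, the lowest of the three numbers known. Among the measured compounds shown here, compound 2 `COc1ccc(C(=O)NCc2ccc(CNS(=O)(=O)c3ccc(C)cc3)cc2)cc1` gives 100 nM, and the step of a 10-fold higher number from compound 1 to compound 2 (1.00 log units; beyond the scatter) is the only measured step that bears on the present question, since it also alters the group on the carbonyl carbon. Compound 3 `O=C(NCc1ccc(CNS(=O)(=O)c2ccccc2)cc1)c1ccccc1F` differs from compound 1 in two places at once. In this assay, for the measured compounds named here, compound 3 gives 1000 nM; its value shows only that compound 3 lies well above compound 1.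

Compound 4 `Cc1ccc(S(=O)(=O)NCc2ccc(CNC(=O)c3c(Cl)cc(Cl)cc3Cl)cc2)cc1` is the untested member. Its change from compound 1 is 2,4,6-trichlorophenyl in place of 4-nitrophenyl on a carbonyl carbon. Nothing measured here reproduces this exact exchange, but the one comparable replacement of the 4-nitrophenyl, in compound 2, raised the number by a modest but clear amount, and compound 3, with a halogen-bearing ring, sits far higher still. Compound 4 is therefore expected to need more compound than compound 1, with an estimated step of a 20-fold higher number from compound 1 to compound 4 (1.30 log units; beyond the scatter). Compound 4 is estimated at 200 nM, within a range of 30 nM to 2000 nM.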

Compound 4, effective concentration (reported as EC, without a stated level of effect): 10 nM
Beside the measured number, compound 4's estimate is 20-fold (1.30 log units) above it, outside the stated range (below it).
By their numbers in this assay, from the lowest: compounds 1 and 4 (each within the scatter of the next); then compound 2; then compound 3.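

In this assay, putting 2,4,6-trichlorophenyl in place of 4-nitrophenyl on a carbonyl carbon whose other neighbours are an amide-type nitrogen gives no change at the digits printed from compound 1 to compound 4 (within the scatter), so a ring carrying no nitrogen or oxygen can stand at this place with the number of compound 1 kept. Among these compounds, this is something the earlier compounds could not show, since the only comparable exchange, in compound 2, had left open whether any departure from 4-nitrophenyl would cost as much. Among the compounds shown here, the new pair answers that: 2,4,6-trichlorophenyl in place of 4-methoxyphenyl gives a 10-fold lower number from compound 2 to compound 4 (1.00 log units; beyond the scatter), so the higher number of compound 2 belongs to its 4-methoxyphenyl and not to the loss of 4-nitrophenyl as such, and compound 2 is the one compound here in which replacing that ring raises the number.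

On these data alone, it remains open which of the three chlorines carry this result, and whether a ring bearing an amine or a carboxylic acid on the same carbonyl carbon would keep the number. Nothing given here accounts for why two such different rings read alike.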